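The source may report more compounds than this note shows. Statements on the series, on what has been measured and on what is new or still open speak of the compounds shown alone.

Measured so far in a functional assay on cells (Oocyte) for inhibition of Voltage-dependent T-type calcium channel subunit alpha-1H (Homo sapiens), tested at 100 uM; a higher number here means more inhibition at the concentration tested (going by the name of the read-out), a lower number less inhibition:

Compound 1, `COC(=O)CC1c2ccccc2N=C(N2CCCCC2)N1C1CCCCC1`: 27%
Compound 2, `COC(=O)CC1c2ccccc2N=C(N2CCOCC2)N1C1CCCCC1`: 12.2%
Compound 3, `O=C(CC1c2ccccc2N=C(N2CCCCC2)N1c1ccccc1)NCc1ccccc1`: 77%

Within this set compound 3 stands highest; its nearest neighbour is compound 1 and the furthest compound 2, both gaps beyond the scatter. How the core of compound 3 differs from the core of compound 1 is not broken down here.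

One change occurs twice among the compounds shown. From compound 1 to compound 2 it is morpholin-4-yl in place of piperidin-1-yl on a carbon with a double bond to nitrogen, and it gave a number 14.8 percentage points lower from compound 1 to compound 2 (beyond the scatter). The unmeasured compound 4, `O=C(CC1c2ccccc2N=C(N2CCOCC2)N1c1ccccc1)NCc1ccccc1`, carries the same kind of change relative to compound 3, namely (morpholin-4-yl in place of piperidin-1-yl on a carbon with a double bond to nitrogen). The surroundings differ: in compound 3 the carbon sits next to the ring atom that bears a phenyl group and two ring bonds from the ring atom that bears a (benzylcarbamoyl)methyl group, whereas in compound 1 it is a cyclohexyl group and a (methoxycarbonyl)methyl group.

Resting on the single earlier step of a number 14.8 percentage points lower from compound 1 to compound 2 (beyond the scatter), a drop of similar size is expected, a number 17 percentage points lower from compound 3 to compound 4 (beyond the scatter), with wider uncertainty because only one example exists and the core differs. Compound 4 is therefore estimated at 60% in this assay, likely between 40% and 78%.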

Compound 4, a percentage reported as inhibition, at one concentration (the size of the read-out at that concentration, not a potency): 63.8%
Estimate against measurement, compound 4: 3.8 percentage points below; low and high end bracket the measured number.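

In this assay, morpholin-4-yl in place of piperidin-1-yl on the carbon with a double bond to nitrogen again gives a drop, a number 13.2 percentage points lower from compound 3 to compound 4 (beyond the scatter). The evidence is two pairs on two cores, and these cores differ in two groups at once, phenyl against cyclohexyl and (benzylcarbamoyl)methyl against (methoxycarbonyl)methyl, so it does not show whether the step would hold on other cores of this series, and a read-out at one concentration says nothing about potency. Within these two pairs the change carries from one core to the other at much the same size: the same change on two cores in this assay, a number 14.8 percentage points lower (beyond the scatter) from compound 1 to compound 2 and a number 13.2 percentage points lower (beyond the scatter) from compound 3 to compound 4, 1.6 percentage points apart, within the scatter of two such steps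

The compounds shown leave open how a different amine on that carbon, such as pyrrolidin-1-yl, 4-methylpiperazin-1-yl or diethylamino, would compare with piperidin-1-yl and morpholin-4-yl. From the compounds shown here alone, it also remains open how much of the difference in level from one core to the other belongs to the phenyl group and how much to the (benzylcarbamoyl)methyl group.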